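This account rests on a few compounds, and the source may have more. Where it says the series, first, only, none or still open, it means among the compounds named here.

Values in a functional assay on HT-29 cells (Homo sapiens) for cytotoxicity, read by MTT assay, with a stated time of 72 h; on this read-out lower numbers stand for stronger inhibition and higher numbers for weaker inhibition:
- compound 1 `Nc1cccc(Nc2c(C(=O)NCc3ccc(F)cc3)nc(Br)c3cccnc23)c1`: > 10000 nM (a limit)
- compound 2 `CC(C)(C)OC(=O)N1CCN(c2c(C(=O)NCc3ccc(F)cc3)nc(Br)c3cccnc23)CC1`: > 10000 nM (a limit)
- compound 3 `CN(C)CCCNc1c(C(=O)NCc2ccc(F)cc2)nc(Br)c2cccnc12`: 6000 nM

Compound 1 gives only a limit, so it has no number to start from. It stands at the limit of > 10000 nM in this assay, at which 2 of the 3 values shown sit.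

Compound 4 `O=C(NCc1ccc(F)cc1)c1nc(Br)c2cccnc2c1N1CCNCC1` carries piperazin-1-yl in place of (3-aminophenyl)amino on an aromatic carbon. Among the compounds with values here, the one measured step that bears on this is an at least 1.6-fold lower number from compound 1 to compound 3 (0.22 log units; that floor lies within the scatter), which also removes the 3-aminophenyl group. Its floor lies within the scatter, so it supports only a modest expected move towards lower numbers in this assay. The expected step is an at least 1.2-fold lower number from compound 1 to compound 4 (0.09 log units; that floor lies within the scatter). For compound 4 the estimated value is 8000 nM, with an expected range of 2500 nM to 20000 nM.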

Compound 4, half-maximal inhibitory concentration: 10000 nM
The estimate for compound 4 lay 1.3-fold (0.10 log units) below the measured number; measured number inside the range.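

In this assay, piperazin-1-yl in place of (3-(dimethylamino)propyl)amino on an aromatic carbon gives a 1.7-fold higher number from compound 3 to compound 4 (0.22 log units; within the scatter), so the two groups cannot be separated at this position. Piperazin-1-yl in place of (3-aminophenyl)amino on an aromatic carbon gives a number no higher from compound 1 to compound 4 (the limit leaves the size open). Hydrogen in place of tert-butoxycarbonyl on an amine nitrogen in a ring gives a number no higher from compound 2 to compound 4 (the limit leaves the size open). The sizes of these two steps cannot be read, as each starts from a limit: the limit of > 10000 nM in this assay, at which 2 of the 4 values shown sit.

On these data alone, it remains open whether a morpholin-4-yl or 4-methylpiperazin-1-yl group, or a longer dialkylaminoalkylamino chain, on this carbon would move the number beyond the scatter. As far as these compounds go, replacing the bromo group is equally open.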